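Compound 3: swapping the benzimidazole substituent at the trifluoromethyl end

This account rests on a few compounds, and the source may have more. Where it says the series, first, only, none or still open, it means among the compounds named here.

In a functional assay on ZR-75-1 cells (Homo sapiens) for inhibition, read by sulforhodamine B assay (on this read-out higher numbers stand for weaker inhibition of growth and lower numbers for stronger inhibition of growth), compound 1 (`Cc1ccc2[nH]c(-c3ccc(-c4ccc(-c5ccc(N(C)C)cc5)cc4)cc3)nc2c1`) gives 7200 nM and compound 2 (`Oc1cccc2[nH]c(-c3ccc(-c4ccc(-c5ccc(C(F)(F)F)cc5)cc4)cc3)nc12`) gives 5110 nM as its value, which places the two within the usual scatter of each other. Among the compounds with values here, compound 2 therefore stands level with the only other measured compound, and no order can be drawn between them.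

Compound 3 (`Cc1ccc2[nH]c(-c3ccc(-c4ccc(-c5ccc(C(F)(F)F)cc5)cc4)cc3)nc2c1`) keeps the trifluoromethyl group of compound 2 and carries 5-methyl-1H-benzimidazol-2-yl in place of 4-hydroxy-1H-benzimidazol-2-yl on an aromatic carbon. Within the data shown here, the data hold no step between measured compounds that differ in one place, so the size of this change cannot be read directly. The entering group also stands on compound 1, which shows 7200 nM in this assay and thus gives no sign of a shift in either direction. The estimated shift is a 1.2-fold higher number from compound 2 to compound 3 (0.07 log units; within the scatter) and is expected to stay within the scatter. For compound 3 the expected value is 6000 nM with an estimated range from 2500 nM to 14000 nM around it.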

Compound 3, concentration for 50% growth inhibition: 2410 nM
Estimate against measurement, compound 3: 2.5-fold (0.40 log units) above; measured number below the stated range.
By their numbers in this assay, from the lowest: compound 3; then compounds 2 and 1 (each within the scatter of the next).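

In this assay, within the data shown here, 5-methyl-1H-benzimidazol-2-yl in place of 4-hydroxy-1H-benzimidazol-2-yl gives a 2.1-fold lower number from compound 2 to compound 3 (0.33 log units; beyond the scatter) with trifluoromethyl held constant, so this aromatic carbon, para to a large group, now has a first step beyond the scatter, though a modest one. With 5-methyl-1H-benzimidazol-2-yl held constant, trifluoromethyl in place of dimethylamino gives a 3.0-fold lower number from compound 1 to compound 3 (0.48 log units; beyond the scatter) and this modest step is also beyond the scatter, so a change at either of these two places on the shared core moves the number, and compound 3 now stands lowest of the three. No measurement at hand accounts for either step.

From the compounds shown here alone, the first step exchanges hydroxy for methyl and also changes where the substituent is named on the benzimidazole, so the contribution of each remains open, as does the standing of an unsubstituted 1H-benzimidazol-2-yl. Also open, going by these compounds, is whether a carboxylic acid or a primary amine in place of trifluoromethyl would continue or reverse the step seen from dimethylamino.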